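The source may report more compounds than this note shows. Statements on the series, on what has been measured and on what is new or still open speak of the compounds shown alone.

Measured so far:
- compound 1, `Cc1ccccc1-c1oc2ccc(C(=O)O)cc2c(=O)c1O`: in a functional assay on the whole organism (stomach) for inhibition, with Rattus norvegicus as the target, at a dose of 80 mg/kg (on this read-out lower numbers stand for less inhibition and higher numbers for more inhibition at the one dose given (going by the name of the read-out)), compound 1 gives 15%
- compound 2, `Cc1ccc(-c2oc3ccc(C(=O)O)cc3c(=O)c2O)cc1`: in this assay compound 2 gives 6%
- compound 3, `COc1ccc(-c2oc3ccc(C(=O)O)cc3c(=O)c2O)cc1`: in this assay compound 3 gives 24%

Compound 2 is the starting point. Its number in this assay cannot be separated from that of compound 1, since a number 9 percentage points lower from compound 1 to compound 2 (within the scatter), whereas compound 3 stands clearly apart from it, since a number 18 percentage points higher from compound 2 to compound 3 (beyond the scatter). Going by the values given here, the next compound, compound 4, has the structure `O=C(O)c1ccc2oc(-c3ccccc3Br)c(O)c(=O)c2c1`; its only change from compound 2 is 2-bromophenyl in place of 4-methylphenyl on an aromatic carbon.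

Among the compounds with values here, two measured steps bear on this. The step from compound 1 to compound 2 moved a methyl group from the 2-position to the 4-position of the phenyl ring and showed a number 9 percentage points lower from compound 1 to compound 2 (within the scatter); the step from compound 2 to compound 3 swapped methyl for methoxy at the 4-position and showed a number 18 percentage points higher from compound 2 to compound 3 (beyond the scatter). Compound 4 combines a return to a 2-substituted phenyl with a new group, bromine, for which no measurement exists. Going back to a 2-substituted phenyl alone would suggest little beyond the scatter, while a change of the group itself produced a modest rise in the one case measured. A small rise is therefore expected, a number 12 percentage points higher from compound 2 to compound 4 (beyond the scatter). For compound 4 in this assay the estimate is 18%, within a range from 5% to 35%.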

Compound 4, a percentage reported as inhibition, in the whole organism at one dose (the size of the read-out at that dose, not a potency): 22%
Estimate against measurement, compound 4: 4 percentage points below; low and high end bracket the measured number.
By their numbers in this assay, from the lowest: compounds 2, 1, 4 and 3 (each within the scatter of the next, the first and the last beyond it).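

In this assay, going by these compounds alone, replacing 4-methylphenyl with 2-bromophenyl on the aromatic carbon next to the ring oxygen gives a number 16 percentage points higher from compound 2 to compound 4 (beyond the scatter) and is the first change at this position to lift the number clearly above that of compound 2 without using methoxy. The comparison with the other 2-substituted phenyl gives a number 7 percentage points higher from compound 1 to compound 4 (within the scatter), so bromo in place of methyl at that ring position cannot be told apart from no change, and bromine cannot be singled out as the source of the rise: compound 1 lies within the scatter of both compound 2 and compound 4, although those two stand apart. Nothing available explains this difference through any property of the groups.

As far as these compounds go, what a 4-bromophenyl would give remains open, and with it the question of whether the place on the phenyl ring or the bromine matters more. Also open is how an amine or a second carboxylic acid on this phenyl ring would read at this dose, and how any of these compounds would behave at other doses.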